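Ethyl to butyl on the shared core

This account rests on a few compounds, and the source may have more. Where it says the series, first, only, none or still open, it means among the compounds named here.

- compound 1 (`CCc1nn(-c2ccc(F)cc2)c2c1CCN(c1ccccc1)C2=O`): (880 nM)
- compound 2 (`CCc1nn(-c2ccc(F)cc2)c2c1CCN(c1cccc(C)c1)C2=O`): (780 nM)

Going by the values given here, in a functional assay on U-937 cells (Homo sapiens), read by cAMP accumulation (on this read-out lower numbers stand for an effect already at smaller amounts and higher numbers for an effect only at larger amounts of compound), compound 1 lies within the scatter of compound 2, its only measured neighbour, so it stands level with the one other number available. The unmeasured compound 3 (`CCCCc1nn(-c2ccc(F)cc2)c2c1CCN(c1ccccc1)C2=O`) differs from compound 1 by one change (ethyl in place of hydrogen on a saturated chain carbon, two bonds along the chain from an aromatic carbon): ethyl in place of hydrogen on a saturated chain carbon, two bonds along the chain from an aromatic carbon, which also reads ethyl to butyl. Among the compounds with values here, the only measured step (a 1.1-fold lower number from compound 1 to compound 2 (0.05 log units; within the scatter)) is a methyl on an aromatic carbon, not a change on this chain, so it offers weak guidance. Within the data shown here, no measured step covers the chain, and no direction can be argued. The expected step (a 1.1-fold lower number from compound 1 to compound 3 (0.04 log units; within the scatter)) is therefore an estimate of no change beyond the scatter. Compound 3 is expected at (800 nM), with an estimated range from (250 nM) to (2500 nM).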

Compound 3, half-maximal effective concentration: 13000 nM
Compound 3: the middle estimate sits 16-fold (1.21 log units) below what was measured; measured number outside the range, above it.
By their numbers in this assay, from the lowest: compounds 2 and 1 (each within the scatter of the next); then compound 3.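

In this assay, the change from ethyl to butyl gives a 15-fold higher number from compound 1 to compound 3 (1.17 log units; beyond the scatter), so this saturated chain carbon, two bonds along the chain from an aromatic carbon, is a place where added carbon moves the number clearly upward. The methyl on the aromatic carbon gave a 1.1-fold lower number from compound 1 to compound 2 (0.05 log units; within the scatter), so the series now holds one change that moves the number beyond the scatter and one that stays within it. Nothing at hand bears on what lies behind the rise.

Open, from the compounds shown here alone, is whether propyl at this place stands with compound 1 or with compound 3, and whether a methyl chain would differ from the ethyl of compound 1. A chain of the same reach ending in an amine or a carboxylic acid also remains an open case.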